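This account rests on a few compounds, and the source may have more. Where it says the series, first, only, none or still open, it means among the compounds named here.

Compound 1, with structure `Cn1ncc2c(=O)n(-c3ccccc3)c(SC(C)(C)c3ccccc3)nc21`, was tested in an assay on isolated protein for inhibition of aldehyde dehydrogenase 1A1 (Homo sapiens) (on this read-out lower numbers stand for stronger inhibition and higher numbers for weaker inhibition), and gave 1900 nM. Among the three measured compounds it carries the highest number, that is the weakest inhibition. Compound 3, with structure `Cn1ccc2c(=O)n(-c3ccccc3)c(SCc3cccc(F)c3)nc21`, gives 930 nM in this assay, a number that sits below that of compound 1 by more than the usual scatter. Compound 2, with structure `Cn1ncc2c(=O)n(-c3ccccc3)c(SCc3cccc(F)c3)cc21`, gives 240 nM in this assay, the lowest of the three numbers and well apart from compound 1. Both compound 2 and compound 3 carry a 3-fluorobenzyl group on the sulfur rather than a branched group, but they differ from compound 1 in their core as well, so their numbers say nothing direct about the change at hand.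

Compound 4, with structure `CCC(Sc1nc2c(cnn2C)c(=O)n1-c1ccccc1)c1ccccc1`, differs from compound 1 only at the sulfur: 1-phenylpropyl in place of 1-methyl-1-phenylethyl on a sulfur. For the measured compounds named here, no measured pair shows this rearrangement, so the direction of the step rests on the open question of how compound 1 behaves once its branching is altered. The author expects a small step from compound 1 to compound 4, of a 1.6-fold lower number from compound 1 to compound 4 (0.20 log units; within the scatter), towards somewhat stronger inhibition but close to the scatter. Compound 4 is accordingly estimated at 1200 nM, within a range from 500 nM to 3000 nM.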

Compound 4, half-maximal inhibitory concentration: 150 nM
The estimate for compound 4 lay 8.0-fold (0.90 log units) above the measured number; the measured number lies below the stated range.
By their numbers in this assay, from the lowest: compounds 4 and 2 (each within the scatter of the next); then compound 3; then compound 1.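

At the sulfur of the shared core, 1-phenylpropyl in place of 1-methyl-1-phenylethyl gives a 13-fold lower number from compound 1 to compound 4 (1.10 log units; beyond the scatter) in this assay, so this position responds strongly to the change. The two groups have the same count of heavy atoms, all carbon, and the same aromatic ring, which means the large step comes with a different joining of those atoms and not with a change in their number or kind. Nothing at hand explains why this rearrangement has so large an effect.

Going by these compounds, it remains open whether a 1-phenylethyl group or a longer chain such as 1-phenylbutyl on the same sulfur would fit the same trend. Also open, on these data alone, is how an amine or a carboxylic acid at the end of that propyl chain would read out.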